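Chloro substitution on the phenyl arm of compound 3

The source may hold more compounds than are shown below. What is called first, only, known or untested is meant among the compounds shown, and "the series" means these compounds.

Compound 3 `Nc1ccccc1NC(=O)CCCCCCc1nc(-c2ccccc2)no1` shares the chain and the five-membered ring core of compound 1 `O=C(CCCCCCc1nc(-c2ccc(F)cc2)no1)NO` and compound 2 `O=C(CCCCCCc1nc(-c2cccs2)no1)NO` but carries a different end group. In an assay on isolated protein for inhibition of histone deacetylase 8 (Homo sapiens), read by fluorescence, with a stated time of 10 min (a lower number here means a stronger inhibitor, a higher number a weaker inhibitor), compound 3 reaches only a limit, > 10000 nM. It thus stands at the limit of > 10000 nM in this assay, at which 1 of the 3 values shown sits, the top of the numbers shown. For the measured compounds named here, compound 1 gives 8760 nM and compound 2 gives 1920 nM; the only measured step, a 4.6-fold lower number from compound 1 to compound 2 (0.66 log units; beyond the scatter), exchanges one aryl group for another and is the nearest comparison. Compound 4 `Nc1ccccc1NC(=O)CCCCCCc1nc(-c2ccccc2Cl)no1` differs from compound 3 by chloro in place of hydrogen on an aromatic carbon. Going by the values given here, no measured step adds a chloro to this ring, so the step that the limit leaves unreadable from compound 3 to compound 4 is expected to be small, with a limit again likely. Compound 4 is estimated at 15000 nM, within 5000 nM to 50000 nM.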

Compound 4, half-maximal inhibitory concentration: > 10000 nM
Compound 4 was reported as a limit; the forecaster's own chance of this, stated with the estimate: 70%; the middle value lies beyond the limit too.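

In this assay compound 3 stands at a limit and compound 4 gives > 10000 nM as a limit too, so the step between them cannot be read. Still open, from the compounds shown here alone, is whether chloro in place of hydrogen changes the number at all with this end group.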